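Methoxy in place of chloro on compound 2

A few compounds are considered here, and "the series" means these few. Any claim that something is new, unique, unknown or untested is made for them only; others in the source may bear on it.

Of the compounds shown here, three on the shared core have been read so far in a functional assay on A549 cells (Homo sapiens) for antiproliferative activity, read by sulforhodamine B assay, with a stated time of 72 h (on this read-out lower numbers stand for stronger inhibition and higher numbers for weaker inhibition), on this series. Compound 1 `O=C(/C=C/c1csc2ccccc12)c1cc(F)ccc1O` gives 7100 nM in that read-out, and compound 3 `O=C(/C=C/c1cc2ccccc2s1)c1cc(Cl)cc(Cl)c1O` gives 6900 nM there, two values within the scatter of each other. Compound 2 `O=C(/C=C/c1cc2ccccc2s1)c1cc(Cl)ccc1O` stands at > 10000 nM and that figure is a limit, not a number. Going by the values given here, it is the only reading of this kind, as the limit of > 10000 nM in this assay, at which 1 of the 3 values shown sits, records for the series.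

Compound 4 `COc1ccc(O)c(C(=O)/C=C/c2cc3ccccc3s2)c1` is next in line and carries methoxy in place of chloro on an aromatic carbon, para to a hydroxy group, with the count as follows: methoxy in place of chloro on an aromatic carbon for the whole change. Among the compounds with values here, one measured step bears on it, and only loosely: an at least 1.4-fold lower number from compound 2 to compound 3 (0.16 log units; that floor lies within the scatter) for chloro in place of hydrogen on an aromatic carbon, and that floor lies within the scatter. Within the data shown here, no measured step replaces chloro with methoxy. No direction is favoured, and no shift beyond the scatter is expected in this assay for this change. The expected step is a step that the limit leaves unreadable from compound 2 to compound 4 in size, and it stays within the scatter. Compound 4 is estimated at 12000 nM with 5000 nM to 30000 nM as the expected range.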

Compound 4, half-maximal inhibitory concentration: > 10000 nM
Compound 4 was reported as a limit (the forecaster's own chance of this, stated with the estimate: 55%); the middle value does not contradict the limit.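

In this assay compound 2 gives > 10000 nM, which is a limit. Compound 4 gives > 10000 nM, also a limit. No step between compound 2 and compound 4 can be read from these two limits: the limit of > 10000 nM in this assay, at which 2 of the 4 values shown sit.

The compounds shown leave open whether methoxy in place of chloro shifts this read-out at all.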